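This account rests on a few compounds, and the source may have more. Where it says the series, first, only, none or still open, it means among the compounds named here.

For the measured compounds named here, compound 1 `c1ccc(Oc2ccccc2C2=NC(c3ccccc3)CO2)cc1` stands at the top of the three numbers measured so far. In a physicochemical assay for lipophilicity (on this read-out lower numbers stand for lower lipophilicity and higher numbers for higher lipophilicity), compound 1 gives 5.61, the highest of the set. Compound 2 `Cc1cccc(C2=NC(c3ccccc3)CO2)c1` is its nearest neighbour: in this assay compound 2 gives 4.11, a number beyond the scatter below that of compound 1. Compound 3 `Fc1cccc(Cl)c1-c1ncco1` lies furthest away: in this assay compound 3 gives 1.89, the lowest value of the three and again beyond the scatter from compound 1.

Compound 4 `COc1ccccc1C1=NC(c2ccccc2)CO1` has not yet been measured. It differs from compound 1 in one place only: methyl in place of phenyl on an oxygen on an aromatic ring. Everything else of compound 1 is kept. Since a phenyl leaves and a single-carbon methyl enters, a downward step in this assay is expected, and one well beyond the scatter rather than a shift within it. The step of a number 1.71 log units lower from compound 1 to compound 4 (beyond the scatter) is therefore expected to be negative. Its size is expected to be comparable to the gap already seen between compound 1 and compound 2. Compound 4 is estimated at 3.9 in this assay, with a range from 3.4 to 4.4.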

Compound 4, partition coefficient: 3.76
For compound 4 the middle estimate is 0.14 log units above the measured one; the range from low to high includes it.
By their numbers in this assay, from the lowest: compound 3; then compound 4; then compound 2; then compound 1.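

For the compounds shown here, until now, no two measured compounds differed in one place only, so none of the gaps could be tied to a single part of the structure. Going by these compounds alone, with the rest of compound 1 kept, methyl in place of phenyl on an oxygen on an aromatic ring gives, in this assay, a number 1.85 log units lower from compound 1 to compound 4 (beyond the scatter), the first step here that can be read at one position. The change from phenoxy to methoxy removes one six-membered aromatic ring of carbon only while the oxygen stays in place, and no measurement at hand bears on why the number moves by this amount.

What happens between these two end points remains open, since the compounds shown carry nothing else on that oxygen, such as an ethyl group, a longer chain or a benzyl group. Also open, from the compounds shown here alone, are whether an amine or a carboxylic acid at this place would move the number up or down, and whether the same change would give a step of similar size on another core.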